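From methylsulfonyl to nitro on the shared core

The source may hold more compounds than are shown below. What is called first, only, known or untested is meant among the compounds shown, and "the series" means these compounds.

Compound 1 `CS(=O)(=O)c1ccc2nc(NC(=O)CCCCCCC(=O)NO)sc2c1`: 5.42 ug/mL
Compound 2 `CS(=O)(=O)c1ccc2nc(NC(=O)CCCCC(=O)NO)sc2c1`: > 30 ug/mL (a limit of the assay, not a number)

Among the compounds with values here, in a functional assay on SW-620 cells (Homo sapiens) for cytotoxicity (on this read-out higher numbers stand for weaker inhibition and lower numbers for stronger inhibition), compound 1 gives 5.42 ug/mL, the only true number so far. Compound 2 gives > 30 ug/mL, which is a limit and not a number. Compound 1 therefore sits at the stronger end of what has been seen, with an at least 5.5-fold higher number from compound 1 to compound 2 (0.74 log units; beyond the scatter) separating the pair, a step beyond the scatter.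

Compound 3 `O=C(CCCCCCC(=O)Nc1nc2ccc([N+](=O)[O-])cc2s1)NO` keeps the chain of compound 1 and changes one group on the core: nitro in place of methylsulfonyl on an aromatic carbon. In words, this is nitro in place of methylsulfonyl on an aromatic carbon. Within the data shown here, the one measured step, an at least 5.5-fold higher number from compound 1 to compound 2 (0.74 log units; beyond the scatter), lies on the saturated chain, so it shows how much the chain matters but does not measure this swap. Among the measured compounds shown here, no measured step touches the methylsulfonyl group, and so neither direction is favoured. No change beyond the scatter is expected in this assay.

The expected step is small, estimated as a 1.2-fold lower number from compound 1 to compound 3 (0.08 log units; within the scatter). For compound 3 the estimated value is 4.5 ug/mL, within an expected range of 1.5 ug/mL to 14 ug/mL.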

Compound 3, half-maximal inhibitory concentration: 0.29 ug/mL
The estimate for compound 3 lay 16-fold (1.19 log units) above the measured number, and the stated range ends above it.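

In this assay the group on this aromatic carbon turns out to matter a great deal: with the chain of compound 1 kept, nitro in place of methylsulfonyl gives a 19-fold lower number from compound 1 to compound 3 (1.27 log units; beyond the scatter) and so moves the read-out towards stronger inhibition. Until now only the saturated chain had shown a step beyond the scatter, and that step ran towards weaker inhibition, so this position on the core is a second place where a single change moves the number strongly, this time in the opposite direction. Methylsulfonyl and nitro match in their hydrogen-bond donors and acceptors, and nothing measured on these two groups tells why the step is so large.

The compounds shown leave open whether another group on this aromatic carbon, such as an amine or a carboxylic acid, would fall nearer to compound 1 or to compound 3. They also leave open whether nitro would bring a similar step on the shorter chain of compound 2 or on a longer chain.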